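The source may report more compounds than this note shows. Statements on the series, on what has been measured and on what is new or still open speak of the compounds shown alone.

Compound 1 `COc1ccc(Nc2nc(Oc3cccc(NC(=O)C=C(C)C)c3)c3sccc3n2)cn1`: 36900 nM
Compound 2 `C/C=C/C(=O)Nc1cccc(Oc2nc(Nc3cccc(C#N)c3)nc3ccsc23)c1`: 47900 nM
Compound 3 `CC(C)=CC(=O)Nc1cccc(Oc2nc(Nc3cccc(C#N)c3)nc3ccsc23)c1`: > 50000 nM

In an ADME assay on L02 cells (Homo sapiens) for inhibition, read by MTT assay, with a stated time of 72 h (on this read-out higher numbers stand for weaker inhibition and lower numbers for stronger inhibition), compound 1 gives 36900 nM and compound 2 gives 47900 nM. For compound 3 the assay returned only a limit, > 50000 nM, so no number is known for it. Compound 3 thus sits at the limit of > 50000 nM in this assay, at which 1 of the 3 values shown sits. Two measured steps lead to compound 3: an at least 1.3-fold higher number from compound 1 to compound 3 (0.13 log units; that floor lies within the scatter) and an at least 1.0-fold higher number from compound 2 to compound 3 (0.01 log units; that floor lies within the scatter), and each floor lies within the scatter. Compound 4 `CCC/C=C/C(=O)Nc1cccc(Oc2nc(Nc3cccc(C#N)c3)nc3ccsc23)c1` differs from compound 3 by pent-1-en-1-yl in place of 2-methylprop-1-en-1-yl on a carbonyl carbon. The step from compound 2 to compound 3 bears on this change, as it also altered the chain on the carbonyl carbon, and its floor lay within the scatter. Compound 4 is therefore expected to show a step that the limit leaves unreadable from compound 3 to compound 4 in this assay, no move beyond the scatter. The estimate for compound 4 is 60000 nM, with a range from 30000 nM to 150000 nM, and a limit may again be all that is reported.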

Compound 4, half-maximal inhibitory concentration: > 50000 nM
Compound 4: only a limit was reported; the forecaster's own chance of this, stated with the estimate: 70%; the middle value does not contradict the limit.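

In this assay compound 4, with pent-1-en-1-yl on the carbonyl carbon, returns only a limit, > 50000 nM. The limit at this position is therefore reached with pent-1-en-1-yl as well as with the 2-methylprop-1-en-1-yl of compound 3: the limit of > 50000 nM in this assay, at which 2 of the 4 values shown sit. Set against the prop-1-en-1-yl compound, the change gives an at least 1.0-fold higher number from compound 2 to compound 4 (0.01 log units; that floor lies within the scatter), while the step between the two limits cannot be read.

As far as these compounds go, how far either compound lies past the limit stays open. So does whether a longer chain, or an amine or carboxylic acid on the chain, would give a measurable number in this assay.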